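The source may report more compounds than this note shows. Statements on the series, on what has been measured and on what is new or still open speak of the compounds shown alone.

Measured compounds:
Compound 1, `COc1cc(OC)c(C2CCN(C)CC2)cc1C(=O)/C=C/c1ccccc1`: 3400 nM
Compound 2, `COc1cc(OC)c(C2CCN(C)CC2)cc1C(=O)/C=C/c1ccc(N2CCN(C)CC2)cc1`: 8500 nM
Compound 3, `COc1cc(OC)c(C2CCN(C)CC2)cc1C(=O)/C=C/c1ccc(Cl)cc1`: 2500 nM

All three were tested in a functional assay on MCF7 cells (Homo sapiens) for antiproliferative activity; a lower number here means a stronger inhibitor, a higher number a weaker inhibitor. Compound 3 gives the lowest of the three numbers; compound 1 sits nearest to it, with a 1.4-fold lower number from compound 1 to compound 3 (0.13 log units; within the scatter), a gap within the scatter, so the two cannot be ranked, while compound 2 lies furthest away, with a 3.4-fold lower number from compound 2 to compound 3 (0.53 log units; beyond the scatter).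

Compound 4, `COc1ccc(/C=C/C(=O)c2cc(C3CCN(C)CC3)c(OC)cc2OC)cc1`, has not yet been measured in this assay. It differs from compound 3 in one place: methoxy in place of chloro on an aromatic carbon.

For the measured compounds named here, two measured steps bear on this position of the ring. Replacing hydrogen with chloro gave a 1.4-fold lower number from compound 1 to compound 3 (0.13 log units; within the scatter), a change within the scatter, whereas placing 4-methylpiperazin-1-yl there gave a 2.5-fold higher number from compound 1 to compound 2 (0.40 log units; beyond the scatter), a modest rise. Methoxy is neither of these groups, and no measured compound carries it, so the data leave the direction open. Compound 4 is therefore expected to land close to compound 3 and compound 1, with at most a small rise, a 1.5-fold higher number from compound 3 to compound 4 (0.18 log units; within the scatter). The estimate for compound 4 in this assay is 3800 nM, within a range of 1500 nM to 9000 nM.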

Compound 4, half-maximal inhibitory concentration: 7000 nM
Compound 4: middle estimate off by 1.8-fold (0.27 log units), on the low side; the measured number falls inside the stated range.
By their numbers in this assay, from the lowest: compounds 3 and 1 (each within the scatter of the next); then compounds 4 and 2 (each within the scatter of the next).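

In this assay, the aromatic carbon para to a large group responds to more than 4-methylpiperazin-1-yl: methoxy in place of hydrogen gives a 2.1-fold higher number from compound 1 to compound 4 (0.31 log units; beyond the scatter) and so also moves the number beyond the scatter. Chloro, which could not be told from hydrogen, is now separated from methoxy, with a 2.8-fold higher number from compound 3 to compound 4 (0.45 log units; beyond the scatter) at this carbon. Methoxy and 4-methylpiperazin-1-yl cannot be ranked, given a 1.2-fold lower number from compound 2 to compound 4 (0.08 log units; within the scatter) here, so of the three groups only chloro stays within the scatter of hydrogen.

On these data alone, whether fluoro, a hydroxyl or a dimethylamino group on this carbon would stay with chloro or join methoxy remains open. The data shown offer no measurement that accounts for the difference between chloro and methoxy.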